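Two Chlorines for a Hydroxyl: Forecasting Compound 3

The source may hold more compounds than are shown below. What is called first, only, known or untested is meant among the compounds shown, and "the series" means these compounds.

Compound 1 `O=C(/C=C\c1ccc(O)cc1)N1N=C(c2ccncc2)OC1c1c[nH]c2ccccc12` stands only at a limit. In an ADME assay on PANC-1 cells (Homo sapiens) for cytotoxicity, read by MTT assay, with a stated time of 48 h (a lower number here means a stronger inhibitor of growth, a higher number a weaker inhibitor of growth), compound 1 gives > 30 ug/mL, which is a limit of the assay and not a number. Compound 2 `COc1ccc(/C=C\C(=O)N2N=C(c3ccncc3)OC2c2c[nH]c3ccccc23)cc1` carries methyl in place of hydrogen on an oxygen on an aromatic ring. In this assay compound 2 likewise gives > 30 ug/mL, again a limit. Among the compounds with values here, the step that the two limits leave unreadable from compound 1 to compound 2 is therefore unreadable, and the only evidence is the limit of > 30 ug/mL in this assay, at which 2 of the 2 values shown sit. Compound 3 `O=C(/C=C/c1c(Cl)cccc1Cl)N1N=C(c2ccncc2)OC1c1c[nH]c2ccccc12` differs from compound 1 by 2-(2,6-dichlorophenyl)ethenyl in place of 2-(4-hydroxyphenyl)ethenyl on a carbonyl carbon. Within the data shown here, no measured step bears on this change, so compound 1 offers no direction for compound 3. The step of a number no higher from compound 1 to compound 3 (the limit leaves the size open) is expected to stay within the scatter. Compound 3 is estimated at 30 ug/mL, between 10 ug/mL and 100 ug/mL, and is expected most likely to return as a limit once more.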

Compound 3, concentration for 50% growth inhibition: > 30 ug/mL
Compound 3 gave a limit, no number (the forecaster's own chance of this, stated with the estimate: 65%); the middle value lies on the limit itself.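

Within the data shown here, compound 1, compound 2 and compound 3 all stand at a limit in this assay and so no step among them can be read: the limit of > 30 ug/mL in this assay, at which 3 of the 3 values shown sit. The compounds shown leave open whether any of these groups on the carbonyl carbon changes growth inhibition at all.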